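Removing the ring-nitrogen substituent from a weak tetrahydroquinoline amide

This account rests on a few compounds, and the source may have more. Where it says the series, first, only, none or still open, it means among the compounds named here.

Measured compounds:
compound 1 `CCC(=O)NCc1ccc2c(OC)cccc2n1` gives > 10000 nM
compound 2 `CCC(=O)NCC1CCc2ccccc2N1CC(=O)NC` gives > 10000 nM
compound 3 `CCC(=O)NCC1CCc2ccc(OC)cc2N1Cc1ccccc1` gives 214 nM

All three values come from an assay on CHO cells for displacement of a labelled ligand from melatonin receptor type 1A (Homo sapiens), with a stated time of 120 min; on this read-out lower numbers stand for stronger inhibition and higher numbers for weaker inhibition. For compound 2 the result is a limit of the assay and not a number: compound 2 shows > 10000 nM. Compound 1 likewise stands at a limit, > 10000 nM. Only compound 3 returns a number, 214 nM, so compound 2 sits at the weak end of what has been seen, in line with the limit of > 10000 nM in this assay, at which 2 of the 3 values shown sit.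

Compound 4 `CCC(=O)NCC1CCc2ccccc2N1` is the unmeasured compound. It differs from compound 2 by hydrogen in place of (methylcarbamoyl)methyl on a nitrogen on an aromatic ring in a ring. Going by the values given here, no measured pair shows this change alone, and compound 3 differs from both in more than one place, so the size of the step is open. Since compound 2 gives only a limit, the step can be told only if compound 4 turns out measurable.

The expected value for compound 4 is 8000 nM, with a range of 1500 nM to 30000 nM. This estimate means a step of an at least 1.2-fold lower number from compound 2 to compound 4 (0.09 log units; that floor lies within the scatter), and the number is expected rather than known.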

Compound 4, inhibition constant: 13 nM
Compound 4: the middle estimate sits 620-fold (2.79 log units) above what was measured; measured number outside the range, below it.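

In this assay, replacing the (methylcarbamoyl)methyl on the nitrogen on an aromatic ring with hydrogen gives an at least 760-fold lower number from compound 2 to compound 4 (2.88 log units; beyond the scatter), so what sits on this one nitrogen can decide between a compound that barely registers and a strong one. Compound 2 stands at a limit of the assay and not at a number, so the printed step is only a floor: the limit of > 10000 nM in this assay, at which 2 of the 4 values shown sit. Going by these compounds alone, no earlier pair changed this place alone, and this pair now shows that the shared core is not weak in itself, since with hydrogen on the nitrogen compound 4 gives 13 nM.

A single pair cannot tell whether the loss in compound 2 comes with any group on this nitrogen or only with this one, and a small methyl or a short chain ending in a carboxylic acid would help to separate the two. Steps involving compound 1 or compound 3 cannot be read, as each differs from compound 4 in more than one place, so the worth of the benzyl group in compound 3 and of a methoxy group on the core also stays open.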